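Adding a pentyl group to an inactive series

The compounds below may be only part of what the source reports. "The series", "measured", "known", "first", "only" and "open" are said of these compounds alone.

Measured in a functional assay on RAW264.7 cells (Mus musculus) for inhibition, read by Griess assay, with a stated time of 20 h (a lower number here means a stronger inhibitor, a higher number a weaker inhibitor), each value a limit:
- Compound 1 `CCCNC(=O)c1ccc(-n2cc(-c3ccccc3)nn2)cc1O`: > 20000 nM
- Compound 2 `CCCNC(=O)c1ccc(-n2cc(-c3cccc(Cl)c3)nn2)cc1O`: > 20000 nM
- Compound 3 `CCCNC(=O)c1ccc(-n2cc(-c3cc(F)cc(F)c3)nn2)cc1O`: > 20000 nM

Compound 1 has no number, only (the limit of > 20000 nM in this assay, at which 3 of the 3 values shown sit). Compound 4 `CCCCCc1ccc(-c2cn(-c3ccc(C(=O)NCCC)c(O)c3)nn2)cc1` differs from compound 1 by one change: pentyl in place of hydrogen on an aromatic carbon. Among the compounds with values here, two measured steps bear on this change, a step that the two limits leave unreadable from compound 1 to compound 2 and a step that the two limits leave unreadable from compound 1 to compound 3, and neither gives a size. The expectation in this assay is therefore loose: a modest move toward stronger inhibition, with a real chance that only a limit is reported again. The estimated step is an at least 1.6-fold lower number from compound 1 to compound 4 (0.22 log units; that floor lies within the scatter). Compound 4 is expected at 12000 nM, with an estimated range of 3000 nM to 30000 nM.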

Compound 4, half-maximal inhibitory concentration: > 20000 nM
Compound 4 was reported as a limit; the forecaster's own chance of this, stated with the estimate: 45%; middle value at least 1.6-fold (0.22 log units) from the limit.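

In this assay, within the data shown here, compound 1 and compound 4 are both reported only as limits, so no step between them can be read: the limit of > 20000 nM in this assay, at which 4 of the 4 values shown sit. The compounds shown leave open whether pentyl, chloro or 3,5-difluorophenyl changes inhibition at all.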